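The compounds below may be only part of what the source reports. "The series", "measured", "known", "first", "only" and "open" are said of these compounds alone.

Measured compounds in an assay on isolated protein for inhibition of serine/threonine-protein kinase PLK1 (Homo sapiens), read by Z'-LYTE, with a stated time of 60 min; a higher number here means a weaker inhibitor, a lower number a stronger inhibitor:
- compound 2 `CC[C@@H]1C(=O)N(C)c2cnc(Nc3ccc(C4CCN(C)CC4)cc3OC)nc2N1C1CCCC1`: 9.9 nM
- compound 3 `CCOc1cc(C(=O)NC2CCN(C)CC2)ccc1Nc1ncc2c(n1)N(C1CCCC1)[C@H](CC)C(=O)N2C`: 12 nM
- compound 1 `CCOc1cc(C2CCN(C)CC2)ccc1Nc1ncc2c(n1)N(Cc1ccc(Br)cc1)[C@H](CC)C(=O)N2C`: "not determined" (no result reported)

Compound 3 gives the higher of the two numbers, but its gap to compound 2 lies within the scatter, so the two read as equivalent. Compound 4 `CCOc1cc(C(=O)NC2CCN(C)CC2)ccc1Nc1ncc2c(n1)N(Cc1cccc(Br)c1)[C@H](CC)C(=O)N2C` differs from compound 3 in one place: 3-bromobenzyl in place of cyclopentyl on a nitrogen on an aromatic ring in a ring. Among the compounds with values here, no measured pair shows this kind of change, and compound 1, the only other entry carrying a bromobenzyl group on that nitrogen, has no reported result, so the direction rests on the change alone. A modest loss is expected from compound 3 to compound 4, a 3.3-fold higher number from compound 3 to compound 4 (0.52 log units; beyond the scatter), beyond the scatter but not large. Compound 4 is estimated at 40 nM, range 10 nM to 200 nM.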

Compound 4, half-maximal inhibitory concentration: 110 nM
Estimate against measurement, compound 4: 2.8-fold (0.44 log units) below; measured number inside the range.
By their numbers in this assay, from the lowest: compounds 2 and 3 (each within the scatter of the next); then compound 4.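

In this assay, within the data shown here, this nitrogen proves sensitive to its substituent: 3-bromobenzyl in place of cyclopentyl gives a 9.2-fold higher number from compound 3 to compound 4 (0.96 log units; beyond the scatter), the first measured change at this position. The change weakens inhibition without abolishing it, so a substituent with a six-membered aromatic ring is accepted here at a cost. Nothing available bears on the origin of this loss.

Going by these compounds, whether the loss follows the benzyl group or its bromine remains open. So does the reading of an unsubstituted benzyl or a smaller isopropyl group at this nitrogen.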